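Working notes: one more chain extension in the series

The source may report more compounds than this note shows. Statements on the series, on what has been measured and on what is new or still open speak of the compounds shown alone.

In a functional assay on PC-3 cells (Homo sapiens) for inhibition (on this read-out higher numbers stand for weaker inhibition and lower numbers for stronger inhibition), compound 2 `O=C(CCCCCCCc1ccccc1)CC(=O)N[C@H]1CCOC1=O` gives 2000 nM, the lower of the two actual numbers in the series. The other number belongs to compound 1 `O=C(CCCCCCCCCc1ccccc1)N[C@H]1CCOC1=O`, at 75000 nM, and the gap between the two lies beyond the scatter. Compound 3 `O=C(CCCCCCCCCCCc1ccccc1)N[C@H]1CCOC1=O` reads > 100000 nM, which is a limit of this assay and not a number.

The next step leads to compound 4 `O=C(CCCCCCCCCc1ccccc1)CC(=O)N[C@H]1CCOC1=O`. The difference is phenethyl in place of phenyl on a saturated chain carbon, seven bonds along the chain from a carbonyl carbon. In words, this is phenethyl in place of phenyl on a saturated chain carbon, seven bonds along the chain from a carbonyl carbon.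

For the measured compounds named here, one measured step bears on this: phenethyl in place of phenyl on a saturated chain carbon, nine bonds along the chain from a carbonyl carbon. It reads an at least 1.3-fold higher number from compound 1 to compound 3 (0.12 log units; that floor lies within the scatter). That step is only a floor, set by the limit of > 100000 nM in this assay, at which 1 of the 3 values shown sits, and it comes from a pair that does not share the chain of compound 2. As far as these compounds go, it points weakly towards a higher number, meaning weaker inhibition, and its size remains open.

A moderate rise is therefore expected, with the estimated step being a 2.5-fold higher number from compound 2 to compound 4 (0.40 log units; beyond the scatter). For compound 4 the estimated value is 5000 nM, with an expected range of 1500 nM to 25000 nM.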

Compound 4, half-maximal inhibitory concentration: 4000 nM
Compound 4: the middle estimate sits 1.3-fold (0.10 log units) above what was measured; the range from low to high includes it.
By their numbers in this assay, from the lowest: compounds 2 and 4 (each within the scatter of the next); then compound 1. At a limit, above all of these: compound 3.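

The change now has a measured size in this assay with a real number at both ends, and the step reads a 2.0-fold higher number from compound 2 to compound 4 (0.30 log units; within the scatter) on the core of compound 2. Phenethyl in place of phenyl, on a saturated chain carbon seven bonds along the chain from a carbonyl carbon, therefore gives no step that can be told from the scatter on this core, which the earlier pair could not show, as it offered only a floor. Read side by side, the two cores cannot yet be separated for this change: the same change on two cores in this assay, an at least 1.3-fold higher number (0.12 log units; that floor lies within the scatter) from compound 1 to compound 3 and a 2.0-fold higher number (0.30 log units; within the scatter) from compound 2 to compound 4; the limit leaves it open whether they differ.

As far as these compounds go, how far the chain on the core of compound 2 can grow remains open, since a longer chain than that of compound 4 could stay within the scatter or could give a clear step to a higher number. Also open, from the compounds shown here alone, is whether the terminal phenyl is needed at all, which an amine or a carboxylic acid in its place on the same chain would test.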